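The source may report more compounds than this note shows. Statements on the series, on what has been measured and on what is new or still open speak of the compounds shown alone.

Compound 2 `CCOC(=O)c1cccc(-c2nc3ccccc3[nH]2)n1` and compound 1 `CCc1cccc(-c2nc3ccccc3[nH]2)n1` share one core. In a functional assay on the whole organism with Rattus norvegicus as the target, read by paw edema, with a stated time of 3 h, at a dose of 100 mg/kg by the oral route (a higher number here means more inhibition at the dose given (going by the name of the read-out), a lower number less inhibition), compound 1 gives 41%, and compound 2 gives 31%. Compound 2 stands lowest of the two numbers, though its gap to compound 1 is within the scatter: a number 10 percentage points lower from compound 1 to compound 2 (within the scatter). Compound 3 `Clc1cccc(-c2nc3ccccc3[nH]2)n1` has not been measured. It differs from compound 2 in one place: chloro in place of ethoxycarbonyl on an aromatic carbon. Among the compounds with values here, no measured pair shows chloro replacing ethoxycarbonyl; the only step at this place, a number 10 percentage points lower from compound 1 to compound 2 (within the scatter), exchanged ethyl for ethoxycarbonyl and stayed within the scatter. Both groups tried at this place gave numbers within the scatter of each other, so no step beyond the scatter is expected for compound 3 in this assay. Compound 3 is estimated at 35%, expected to lie between 18% and 52%. The step this estimate means is a number 4 percentage points higher from compound 2 to compound 3 (within the scatter).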

Compound 3, a percentage reported as inhibition, in the whole organism at one dose (the size of the read-out at that dose, not a potency): 30%
Compound 3: the middle estimate sits 5 percentage points above what was measured, and the stated range covers the measured number.
By their numbers in this assay, from the lowest: compounds 3, 2 and 1 (each within the scatter of the next, the first and the last beyond it).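

Swapping ethoxycarbonyl, with its 5 heavy atoms, for chloro, with 1, at this aromatic carbon next to the ring nitrogen left the result in this assay within the scatter (a number 1 percentage points lower from compound 2 to compound 3 (within the scatter)), so this large difference in group size did not register as a clear step here. The same series gave its first step beyond the scatter, though a modest one, between the two smaller groups (a number 11 percentage points lower from compound 1 to compound 3 (beyond the scatter)), while ethoxycarbonyl stays within the scatter of both. Nothing available explains why ethyl and chloro separate. The compounds shown leave open how an amine, a carboxylic acid or a longer alkyl chain at this place would read in this assay. They also leave open whether ethyl's position above chloro would hold for other small groups.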